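Replacing the Indole with a Vinylphenyl Group

A few compounds are considered here, and "the series" means these few. Any claim that something is new, unique, unknown or untested is made for them only; others in the source may bear on it.

Of the compounds shown here, three on a shared core have been measured in a functional assay on MCF7 cells (Homo sapiens) for inhibition, read by CCK-8 assay, with a stated time of 48 h; a lower number here means a stronger inhibitor, a higher number a weaker inhibitor. Compound 1 `Cn1ccc2cc(-c3cc4nccc(-c5ccc(F)cc5)n4n3)ccc21` gives 4580 nM. Compound 2 `COc1cc(-c2ccnc3cc(-c4c[nH]c5ccccc45)nn23)cc(OC)c1OC` gives 85 nM, and compound 3 `COc1cc(-c2ccnc3cc(-c4cn(CO)c5ccccc45)nn23)cc(OC)c1OC` gives 19 nM. Compound 2 thus stands second highest of the three numbers: its nearest neighbour is compound 3, reached by a 4.5-fold lower number from compound 2 to compound 3 (0.65 log units; beyond the scatter), while compound 1 lies much higher.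

Compound 4 `C=Cc1ccc(-c2cc3nccc(-c4cc(OC)c(OC)c(OC)c4)n3n2)cc1` differs from compound 2 in one place: 4-vinylphenyl in place of 1H-indol-3-yl on an aromatic carbon. For the measured compounds named here, no measured step covers this change directly. Going by the values given here, the only step on record, a 4.5-fold lower number from compound 2 to compound 3 (0.65 log units; beyond the scatter), touches the indole nitrogen rather than removing the indole, so it bears on the new compound only loosely. Among the compounds with values here, compound 1, which also carries no trimethoxyphenyl, shows a far higher number than compound 2, but the two differ in more than one place, so no step can be drawn between them. Given the loss of the hydrogen-bond donor counted in the change, compound 4 is expected to lose potency, with a 9.4-fold higher number from compound 2 to compound 4 (0.97 log units; beyond the scatter) estimated. Compound 4 is therefore estimated at 800 nM, with a range from 150 nM to 4000 nM.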

Compound 4, half-maximal inhibitory concentration: 193 nM
The estimate for compound 4 lay 4.1-fold (0.62 log units) above the measured number; low and high end bracket the measured number.
By their numbers in this assay, from the lowest: compound 3; then compound 2; then compound 4; then compound 1.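

Exchanging 1H-indol-3-yl for 4-vinylphenyl on this aromatic carbon gave a 2.3-fold higher number from compound 2 to compound 4 (0.36 log units; beyond the scatter) in this assay, a modest step. At this position, then, compound 4 keeps much of the inhibition of compound 2 even though the five-membered aromatic ring and the hydrogen-bond donor of the indole are gone and a double bond outside the aromatic rings has entered. Nothing measured here accounts for the size of this step.

The compounds shown leave open whether an amine, a carboxylic acid or a longer chain in place of the vinyl group would narrow this gap. Also open, from the compounds shown here alone, is whether hydroxymethyl, which gave a 4.5-fold lower number from compound 2 to compound 3 (0.65 log units; beyond the scatter) on the indole nitrogen, would bring any gain when attached to the 4-vinylphenyl group.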